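This account rests on a few compounds, and the source may have more. Where it says the series, first, only, none or still open, it means among the compounds named here.

Measured so far in an assay on HEK293 cells for positive allosteric modulation of metabotropic glutamate receptor 5 (Homo sapiens), read by FLIPR, with a stated time of 1 h; on this read-out lower numbers stand for an effect already at smaller amounts and higher numbers for an effect only at larger amounts of compound:
compound 1 `O=C(C1CC12CCC2)N1CCc2nc(C#Cc3ccccc3)sc2C1`: 3.9 nM
compound 2 `O=C(C1CCC1)N1CCc2nc(C#Cc3ccccc3)sc2C1`: > 10000 nM

Compound 2 stands at the limit of this assay; its value is not a number but (the limit of > 10000 nM in this assay, at which 1 of the 2 values shown sits). Among the measured compounds shown here, the one measured step, an at least 2500-fold higher number from compound 1 to compound 2 (3.40 log units; beyond the scatter), replaces on the carbonyl carbon the group with a three-membered and a four-membered ring by the plain four-membered ring. Compound 3 `CC1CC(C(=O)N2CCc3nc(C#Cc4ccccc4)sc3C2)C1` differs from compound 2 by methyl in place of hydrogen on a saturated ring carbon, read as cyclobutyl to 3-methylcyclobutyl. The measured step bears on this only indirectly: it shows that taking carbons away at this place costs a great deal, so putting one carbon back may recover part of the loss, though the new carbon does not rebuild the lost ring. Compound 3 is therefore expected to improve, an at least 3.3-fold lower number from compound 2 to compound 3 (0.52 log units; beyond the scatter). The estimate for compound 3 in this assay is 3000 nM, within a range from 300 nM to 30000 nM.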

Compound 3, half-maximal effective concentration: 81 nM
Compound 3: middle estimate off by 37-fold (1.57 log units), on the high side; measured number outside the range, below it.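

In this assay, the change from cyclobutyl to 3-methylcyclobutyl alone gives a large recovery (an at least 120-fold lower number from compound 2 to compound 3 (2.09 log units; beyond the scatter)), so one added carbon on this saturated ring carbon, with no second ring, restores a substantial part of what the plain cyclobutyl group lost. The recovery is incomplete (a 21-fold higher number from compound 1 to compound 3 (1.32 log units; beyond the scatter)), which leaves the group with a three-membered and a four-membered ring ahead of 3-methylcyclobutyl by more than the scatter. The first of these steps is only a lower bound, because compound 2 has a limit and not a number: the limit of > 10000 nM in this assay, at which 1 of the 3 values shown sits.

Open, as far as these compounds go, is whether ethyl or a second methyl on the same ring carbon would move the number closer to that of compound 1. Also open, from the compounds shown here alone, is how a hydroxyl or an amine would fare at this place.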